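The source may report more compounds than this note shows. Statements on the series, on what has been measured and on what is new or still open speak of the compounds shown alone.

Measured in a functional assay on MCF7 cells (Homo sapiens) for antiproliferative activity, read by sulforhodamine B assay, with a stated time of 48 h; a higher number here means a weaker inhibitor, a lower number a stronger inhibitor:
- compound 1 `CCCCN(C)C(=O)CCCOc1cc(OC)c(OC)c2oc(-c3ccc(OC)cc3)c(O)c(=O)c12`: > 40000 nM (a limit)
- compound 2 `COc1ccc(-c2oc3c(OC)c(OC)cc(OCCCC(=O)NCc4ccccn4)c3c(=O)c2O)cc1`: > 40000 nM (a limit)
- compound 3 `CCCCN(C)C(=O)CCCCOc1cc(OC)c(OC)c2oc(-c3ccc(OC)cc3)c(O)c(=O)c12`: 22300 nM

Going by the values given here, compound 3 carries the only actual number, 22300 nM. The other two results are limits, and the evidence on them is the limit of > 40000 nM in this assay, at which 2 of the 3 values shown sit.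

Compound 4 `COc1ccc(-c2oc3c(OC)c(OC)cc(OCCCCC(=O)NCc4ccccn4)c3c(=O)c2O)cc1` differs from compound 3 by ((pyridin-2-yl)methyl)amino in place of butyl(methyl)amino on a carbonyl carbon. In short, ((pyridin-2-yl)methyl)amino stands in place of butyl(methyl)amino on a carbonyl carbon.

The same exchange occurs once among the measured pairs, as a step that the two limits leave unreadable from compound 1 to compound 2, so it offers no size to carry over. The other two steps are an at least 1.7-fold lower number from compound 1 to compound 3 (0.25 log units; that floor lies within the scatter) and an at least 1.7-fold lower number from compound 2 to compound 3 (0.25 log units; that floor lies within the scatter). Both give only floors within the scatter, and neither fixes a size for this exchange.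

With no readable precedent, no step beyond the scatter is expected in this assay, and a result at the limit remains possible. The expected step is a 1.3-fold higher number from compound 3 to compound 4 (0.13 log units; within the scatter). For compound 4 the estimated value is 30000 nM, with an expected range of 13000 nM to 60000 nM.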

Compound 4, half-maximal inhibitory concentration: > 40000 nM
Compound 4: no number, only a limit (the forecaster's own chance of this, stated with the estimate: 45%); middle value at least 1.3-fold (0.12 log units) away from the limit.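

In this assay the exchange of butyl(methyl)amino for ((pyridin-2-yl)methyl)amino on a carbonyl carbon now gives a readable step (an at least 1.7-fold higher number from compound 3 to compound 4 (0.25 log units; that floor lies within the scatter)), which the pair of compound 1 and compound 2 could not provide. That step is only a floor, as compound 4 has a limit and no number, so the exchange has a direction here but no fixed size. The steps from compound 1 and from compound 2 to compound 4 cannot be read, and the series now consists mostly of limits: the limit of > 40000 nM in this assay, at which 3 of the 4 values shown sit.

Going by these compounds alone, compound 3 remains the only compound with a number, so the true size of this exchange stays open. Also open, from the compounds shown here alone, is whether a carboxylic acid, a tertiary amine or a longer chain at this place would give a number rather than a limit.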